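Cyclopropyl for vinyl on the chain of compound 3

A few compounds are considered here, and "the series" means these few. Any claim that something is new, unique, unknown or untested is made for them only; others in the source may bear on it.

Measured in a functional assay on MCF7 cells (Homo sapiens) for cytotoxicity, read by MTT assay, with a stated time of 48 h; on this read-out lower numbers stand for stronger inhibition of growth and higher numbers for weaker inhibition of growth:
Compound 1 `Cn1c(C(F)(F)F)nc2cc(Cl)c(Cl)cc21` gives 39000 nM
Compound 2 `CCn1c(C(F)(F)F)nc2cc(Cl)c(Cl)cc21` gives 72900 nM
Compound 3 `C=CCn1c(C(F)(F)F)nc2cc(Cl)c(Cl)cc21` gives 87000 nM

On these numbers, compound 3 lies level with one measured neighbour and higher than the other (a 1.2-fold higher number from compound 2 to compound 3 (0.08 log units; within the scatter) and a 2.2-fold higher number from compound 1 to compound 3 (0.35 log units; beyond the scatter)). Compound 4 `FC(F)(F)c1nc2cc(Cl)c(Cl)cc2n1CC1CC1` differs from it by one change (cyclopropyl in place of vinyl on a saturated chain carbon bound to an aromatic nitrogen): cyclopropyl in place of vinyl on a saturated chain carbon bound to an aromatic nitrogen. Among the measured compounds shown here, no measured step tests cyclopropyl. Methyl in place of hydrogen on that carbon gave a 1.9-fold higher number from compound 1 to compound 2 (0.27 log units; within the scatter) and vinyl in place of methyl also stayed within the scatter. No step beyond the scatter is therefore expected in this assay and the estimated change is small (a 1.1-fold lower number from compound 3 to compound 4 (0.04 log units; within the scatter)). Compound 4 is expected at 80000 nM (estimated range from 40000 nM to 160000 nM).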

Compound 4, concentration for 50% growth inhibition: 60200 nM
For compound 4 the middle estimate is 1.3-fold (0.12 log units) above the measured one; the measured number falls inside the stated range.
By their numbers in this assay, from the lowest: compounds 1, 4, 2 and 3 (each within the scatter of the next, the first and the last beyond it).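

Cyclopropyl brings the first ring to this place, and in this assay the steps of a 1.4-fold lower number from compound 3 to compound 4 (0.16 log units; within the scatter) and a 1.2-fold lower number from compound 2 to compound 4 (0.08 log units; within the scatter) and a 1.5-fold higher number from compound 1 to compound 4 (0.19 log units; within the scatter) all stay within the scatter. Unlike compound 3, compound 4 therefore cannot be told apart from compound 1. No measurement is available that would explain these numbers. On these data alone, it remains open whether an amine, a carboxylic acid or a longer chain at this place would give a step beyond the scatter, and whether any group there could give a lower number than compound 1 does.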